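The compounds below may be only part of what the source reports. "The series", "measured", "known", "first", "only" and "open" are said of these compounds alone.

Of the compounds shown here, two have been measured so far in a functional assay on MOLT-4 cells (Homo sapiens) for cytotoxicity, with a stated time of 72 h; a higher number here means a weaker inhibitor, a lower number a stronger inhibitor. Compound 1 `Cc1ccc(/C=C2\CCC/C(=C\c3ccc([N+](=O)[O-])cc3)C2=O)cc1` gives 8440 nM, and compound 2 `O=C1/C(=C/c2ccccc2)CCC/C1=C\c1ccc([N+](=O)[O-])cc1` gives 8350 nM. The only difference between them is hydrogen in place of methyl on an aromatic carbon, and that step, a 1.0-fold lower number from compound 1 to compound 2 (0.00 log units; within the scatter), shows nothing beyond the scatter. Compound 2 thus holds the lower of the two numbers, but nothing separates it from compound 1.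

Compound 3 `COc1ccc(/C=C2\CCC/C(=C\c3ccc([N+](=O)[O-])cc3)C2=O)cc1` has not yet been measured. It differs from compound 2 by methoxy in place of hydrogen on an aromatic carbon. Going by the values given here, the measured step from compound 1 to compound 2 also exchanged a small group on an aromatic carbon, and it is the only guide available here. Since that step was flat, the expectation is that putting methoxy in that place behaves in the same way, with no step beyond the scatter in this assay. The estimate for compound 3 is therefore 8000 nM, within a range from 4000 nM to 16000 nM, which corresponds to an expected step of a 1.0-fold lower number from compound 2 to compound 3 (0.02 log units; within the scatter).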

Compound 3, half-maximal inhibitory concentration: 300000 nM
Beside the measured number, compound 3's estimate is 38-fold (1.57 log units) below it, and the stated range ends below it.
By their numbers in this assay, from the lowest: compounds 2 and 1 (each within the scatter of the next); then compound 3.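

In this assay, this position on a six-membered aromatic ring of carbon only, para to a large group, turns out not to be indifferent to what sits on it: methoxy in place of hydrogen gives a 36-fold higher number from compound 2 to compound 3 (1.56 log units; beyond the scatter), and methoxy in place of methyl gives a 36-fold higher number from compound 1 to compound 3 (1.55 log units; beyond the scatter). Going by these compounds alone, the earlier exchange of methyl for hydrogen, a 1.0-fold lower number from compound 1 to compound 2 (0.00 log units; within the scatter), therefore showed only that these two groups cannot be told apart here, not that any small group would be accepted, and the two large steps show that compound 3 is clearly the weakest of the three in this cytotoxicity read-out. Nothing measured here says what lies behind this large change in the number, so the finding remains a plain observation about the methoxy group.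

On these data alone, three groups at one position are too few to show a trend, so it remains open whether the loss belongs to methoxy alone. A hydroxy group, a fluorine atom, an ethoxy group or an amine at this position could each help to show how far the loss extends beyond methoxy.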